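Swapping a nitrate chain for an oxadiazole ring

The source may report more compounds than this note shows. Statements on the series, on what has been measured and on what is new or still open speak of the compounds shown alone.

Measured compounds:
- compound 1 `COC(=O)C1=C(C)N=C(C)/C(=C(/O)OC)C1c1ccccc1OCCO[N+](=O)[O-]`: 38 nM
- compound 2 `COC(=O)C1=C(C)N=C(C)/C(=C(/O)OC)C1c1cccc(OCc2no[n+]([O-])c2C)c1`: 370 nM
- compound 3 `COC(=O)C1=C(C)N=C(C)/C(=C(/O)OC)C1c1cccc(OCc2c(C(N)=O)no[n+]2[O-])c1`: 1600 nM

In an assay on Cortex for displacement of a labelled ligand from Voltage-dependent L-type calcium channel subunit alpha-1D (Rattus norvegicus) (on this read-out higher numbers stand for weaker inhibition and lower numbers for stronger inhibition), compound 1 gives 38 nM, the lowest of the three numbers and therefore the strongest inhibition seen here; compound 2 gives 370 nM and compound 3 gives 1600 nM, both beyond the scatter away from compound 1.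

Compound 4 `COC(=O)C1=C(C)N=C(C)/C(=C(/O)OC)C1c1ccccc1OCc1nonc1C` keeps the shared core of compound 1 and differs only in one place: 4-methyl-1,2,5-oxadiazol-3-yl in place of (nitrooxy)methyl on a saturated chain carbon bound to an oxygen on an aromatic ring. Among the compounds with values here, the only measured step, a 4.3-fold higher number from compound 2 to compound 3 (0.64 log units; beyond the scatter), concerns an exchange within a ring substituent on compounds that already carry a five-membered aromatic ring, so it does not show what replacing the nitrate chain by such a ring does. Compound 2, which carries a ring of this kind, is weaker than compound 1, but it also differs from compound 1 elsewhere, so its value gives only loose guidance.

Within the data shown here, with no direct precedent, only a modest weakening is expected, a 1.8-fold higher number from compound 1 to compound 4 (0.27 log units; within the scatter), and the wide range reflects that uncertainty. Compound 4 is expected to give 70 nM, estimated between 15 nM and 350 nM.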

Compound 4, inhibition constant: 27 nM
Beside the measured number, compound 4's estimate is 2.6-fold (0.41 log units) above it, and the stated range covers the measured number.
By their numbers in this assay, from the lowest: compounds 4 and 1 (each within the scatter of the next); then compound 2; then compound 3.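

In this assay, putting 4-methyl-1,2,5-oxadiazol-3-yl in place of (nitrooxy)methyl on a saturated chain carbon bound to an oxygen on an aromatic ring gives a 1.4-fold lower number from compound 1 to compound 4 (0.15 log units; within the scatter), so the assay does not separate the two compounds. Within the data shown here, this is the first direct comparison of the nitrate chain with a ring at this place, and it shows that the nitrate group is not needed to keep a number of this size. No measurement shown here explains why the two groups read alike.

Compound 2 and compound 3 differ from compound 4 in more than one place, so they cannot show how other changes to this ring would read. As far as these compounds go, it also remains open whether an amine or a carboxylic acid in place of the ring's methyl would keep the number.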